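The compounds below may be only part of what the source reports. "The series", "measured", "known", "first", "only" and "open" are said of these compounds alone.

Measured so far in an assay on isolated protein for inhibition of Amine oxidase [flavin-containing] A (Homo sapiens), read by Amplex Red, with a stated time of 15 min, tested at 100 uM; a lower number here means less inhibition, a higher number more inhibition at the concentration tested (going by the name of the read-out):
compound 1, `CC(=O)c1ccc(OCc2cccc(C)c2)cc1`, gives 32.3%
compound 2, `CC(=O)c1ccc(OCc2cccc(C(F)(F)F)c2)cc1`, gives 48.9%
compound 3, `CC(=O)c1cccc(OCc2ccc(C)cc2)c1`, gives 23%

Compound 4, `CC(=O)c1cccc(OCc2ccc(C(F)(F)F)cc2)c1`, has not yet been measured in this assay. It is related to compound 3 by one change: trifluoromethyl in place of methyl on an aromatic carbon. The same change is seen between compound 1 and compound 2: trifluoromethyl in place of methyl on an aromatic carbon. That step gave a number 16.6 percentage points higher from compound 1 to compound 2 (beyond the scatter).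

The two pairs do not share a core. Compound 1 and compound 3 are built from the same atoms joined differently, but the difference between the two cores is not broken down here. The place of the change also differs in one word: in compound 2 the entering group sits meta to a large group, whereas in compound 4 it sits para to a large group. The change from compound 3 to compound 4 is therefore the same kind of change as from compound 1 to compound 2, not the same change.

Compound 3 has the lowest of the three numbers, though its gap to compound 1 lies within the scatter. Resting on the measured step from compound 1 to compound 2, the step from compound 3 to compound 4 is expected to be a number 15 percentage points higher from compound 3 to compound 4 (beyond the scatter), with a wider range than that step because the place differs. Compound 4 is therefore estimated at 38%, most likely between 22% and 55%.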

Compound 4, a percentage reported as inhibition, at one concentration (the size of the read-out at that concentration, not a potency): 27.2%
Compound 4: the middle estimate sits 10.8 percentage points above what was measured; the range from low to high includes it.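

In this assay putting trifluoromethyl in place of methyl gives a number 4.2 percentage points higher from compound 3 to compound 4 (within the scatter) and so, on this core, the swap cannot be told apart from no effect. The earlier step on the core of compound 1 was beyond the scatter, yet the two steps do not differ by more than repeated measurements could explain: the same change on two cores in this assay, a number 16.6 percentage points higher (beyond the scatter) from compound 1 to compound 2 and a number 4.2 percentage points higher (within the scatter) from compound 3 to compound 4, 12.4 percentage points apart, within the scatter of two such steps

Among these compounds, this means the series neither proves that the change carries over from one core to the other nor proves that it fails to, since each core offers only one pair, and the entering group also sits in a different place in each pair. As far as these compounds go, how much of the gap comes from the core, the place or plain scatter stays unknown.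

The compounds shown leave open how this pattern would look with both groups compared at one place on both cores. They also leave open what a chlorine atom, a methoxy group or an amine would do in place of methyl on either core.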